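Pyridyl isomer change in the imidazoline ether series

The source may hold more compounds than are shown below. What is called first, only, known or untested is meant among the compounds shown, and "the series" means these compounds.

Compound 1 `CCN(CC)C(=O)c1ccccc1OCC1=NCCN1` is read in a functional assay for activation of Alpha-1A adrenergic receptor (Homo sapiens), read by calcium flux (a higher number here means that more compound is needed for the effect, a lower number that less compound is needed), only as a limit, < 5020 nM, not as a number. Within the data shown here, compound 2 `c1cncc(-c2ccccc2OCC2=NCCN2)c1` gives 2 nM in this assay, the only number in the set so far. Among the measured compounds shown here, the one other value shown is a limit (the limit of < 5020 nM in this assay, at which 1 of the 2 values shown sits), so compound 2 has no measured neighbour against which its potency can be ranked.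

Compound 3 `c1ccc(-c2ccncc2)c(OCC2=NCCN2)c1` is not yet measured. It differs from compound 2 by pyridin-4-yl in place of pyridin-3-yl on an aromatic carbon, the atoms being the same and only joined differently. For the measured compounds named here, no step between two measured compounds is available, so the size of this move rests on the change alone. A modest loss, somewhat beyond the usual scatter, is expected, a 4.0-fold higher number from compound 2 to compound 3 (0.60 log units; beyond the scatter). Compound 3 is estimated at 8 nM in this assay, with a range from 2 nM to 40 nM.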

Compound 3, half-maximal effective concentration: < 100000 nM
Compound 3: a limit, no number (the forecaster's own chance of this, stated with the estimate: 5%); the middle value lies beyond the limit too.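

In this assay, among these compounds, compound 3 gives < 100000 nM, a limit and not a number, so no step from compound 2 to compound 3 can be read. The compounds shown leave open how far, and in which direction, pyridin-4-yl in place of pyridin-3-yl shifts potency.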